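A few compounds are considered here, and "the series" means these few. Any claim that something is new, unique, unknown or untested is made for them only; others in the source may bear on it.

Measured compounds and their values:

Compound 1, `Nc1cccc(CNc2cc(C(F)(F)F)cc3[nH]ncc23)c1`: in an assay for inhibition of Tryptophan 2,3-dioxygenase (Homo sapiens), with stated times of 10 min and 60 min, tested at 100 uM (on this read-out higher numbers stand for a stronger effect at the one concentration tested and lower numbers for a weaker effect), compound 1 gives 89%.
Compound 2, `O=[N+]([O-])c1ccc(O)cc1CNc1cc(Br)cc2[nH]ncc12`: in this assay compound 2 gives 99%.
Compound 3, `Cc1ccc(CNc2cc(C(F)(F)F)cc3[nH]ncc23)c([N+](=O)O)c1`: in this assay compound 3 gives 92%.

All three compounds share a core and differ in the groups attached around it. The three numbers lie close together, and each pair of them falls within the usual scatter of repeated measurements, so compound 1 cannot be set apart from compound 2 or compound 3 on these numbers alone; all three show a strong effect at the single concentration tested.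

The next compound, compound 4, `FC(F)(F)c1cc(NCc2cccc(Br)c2)c2cn[nH]c2c1`, is built from compound 1 by a single exchange: bromo in place of amino on an aromatic carbon. For the measured compounds named here, no pair of measured compounds differs by this same exchange, so there is no measured step to lean on. Since the three measured compounds all give high numbers despite differing in several places, the expectation is a step within the scatter, if any, possibly a small one downward, and the step from a number 4 percentage points lower from compound 1 to compound 4 (within the scatter) is estimated accordingly. Compound 4 is therefore expected to give about 85%, within a range from 65% to 97%.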

Compound 4, a percentage reported as inhibition, at one concentration (the size of the read-out at that concentration, not a potency): 84%
Compound 4: middle estimate off by 1 percentage points, on the high side; measured number inside the range.
By their numbers in this assay, from the lowest: compounds 4, 1, 3 and 2 (each within the scatter of the next, the first and the last beyond it).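

In this assay, placing bromo where compound 1 carries amino gives a number 5 percentage points lower from compound 1 to compound 4 (within the scatter). For the compounds shown here, this is the first pair among the compounds that differs in one place only, and it shows that this aromatic carbon can lose amino, with its hydrogen-bond donor and acceptor, to bromo, which has neither, without a change beyond the scatter. Nothing measured here bears on the reason for this result.

Still open, on these data alone, is whether other groups at this same place, such as a carboxylic acid, a methoxy group or a longer chain, would keep the read-out in the same range. As far as these compounds go, a read-out at one concentration is not a potency, so whether compound 1 and compound 4 differ in potency also remains unknown.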